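Adding an Amino Group to Compound 2

The compounds below may be only part of what the source reports. "The series", "measured", "known", "first", "only" and "open" are said of these compounds alone.

Compound 1 `ClCc1ccccc1Cn1cnc2c(Cl)nc(Cl)nc21`: 420 nM
Compound 2 `ClCc1ccccc1Cn1cnc2c(Cl)ncnc21`: 3540 nM
Compound 3 `ClCc1ccccc1Cn1cnc2ncnc(Cl)c21`: 3890 nM

In a functional assay on HT-29 cells (Homo sapiens) for cytotoxicity, read by sulforhodamine B assay, with a stated time of 48 h (on this read-out lower numbers stand for stronger inhibition of growth and higher numbers for weaker inhibition of growth), compound 2 gives 3540 nM, the second highest of the three numbers. Compound 3 at 3890 nM lies within the scatter of it, whereas compound 1 gives 420 nM. For the measured compounds named here, compound 4 `Nc1nc(Cl)c2ncn(Cc3ccccc3CCl)c2n1` carries the change amino in place of hydrogen on an aromatic carbon at the same aromatic carbon where the one measured step, an 8.4-fold higher number from compound 1 to compound 2 (0.93 log units; beyond the scatter), replaced chloro by hydrogen. Going by the values given here, that step shows the carbon is sensitive to what sits on it, but no measured pair shows what an amino group does there, so the direction is open. Compound 4 is therefore expected to land near compound 2, with an estimated step of a 1.2-fold lower number from compound 2 to compound 4 (0.07 log units; within the scatter) in this assay that need not exceed the scatter. The estimate for compound 4 is 3000 nM, ranging from 800 nM to 11000 nM.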

Compound 4, concentration for 50% growth inhibition: 3890 nM
Estimate against measurement, compound 4: 1.3-fold (0.11 log units) below, within the range that was stated.
By their numbers in this assay, from the lowest: compound 1; then compounds 2, 3 and 4 (each within the scatter of the next).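

In this assay, the exchange of hydrogen for an amino group on this aromatic carbon between two ring nitrogen atoms reads as a 1.1-fold higher number from compound 2 to compound 4 (0.04 log units; within the scatter), so hydrogen and amino cannot be told apart here. Of the three groups at this carbon, only chloro stands apart: the step to amino is a 9.3-fold higher number from compound 1 to compound 4 (0.97 log units; beyond the scatter), of a size with the step to hydrogen. No measurement available here accounts for this. 

The compounds shown leave open how other groups would read at this carbon, such as bromo, methoxy or a methylamino group, and so whether anything besides chloro gives the lower number.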